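Swapping a hydroxyl tail for a pyrazole ring

The source may report more compounds than this note shows. Statements on the series, on what has been measured and on what is new or still open speak of the compounds shown alone.

Of the compounds shown here, three built on a shared core have been tested in an assay on HEK293 cells for agonist activity at Toll-like receptor 8 (Homo sapiens), read by spectrophotometry; on this read-out lower numbers stand for an effect already at smaller amounts and higher numbers for an effect only at larger amounts of compound. Compound 1 `CCCCNc1nc(N)nc(C)c1CCCCc1ccccc1` gives 857 nM, compound 2 `CCCCNc1nc(N)nc(C)c1CCCN1CCN(C)CC1` gives 179 nM, and compound 3 `CCCCNc1nc(N)nc(C)c1CCCCO` gives 1310 nM. Compound 3 is separated from compound 1 by a 1.5-fold higher number from compound 1 to compound 3 (0.18 log units; within the scatter), so these two cannot be told apart, while a 7.3-fold higher number from compound 2 to compound 3 (0.86 log units; beyond the scatter) places compound 3 clearly behind compound 2.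

Compound 4 `CCCCNc1nc(N)nc(C)c1CCCn1cccn1` differs from compound 3 in one place: 1H-pyrazol-1-yl in place of hydroxymethyl on a saturated chain carbon, three bonds along the chain from an aromatic carbon. The step that bears most directly on this is a 7.3-fold higher number from compound 2 to compound 3 (0.86 log units; beyond the scatter), which shows that a nitrogen-containing group in this position can matter. The step of a 1.5-fold higher number from compound 1 to compound 3 (0.18 log units; within the scatter) shows that a flat aromatic ring there gives much the same result as the hydroxyl. The pyrazole is an aromatic ring rather than a basic amine, so a change similar in size to the phenyl case, or a modest gain, is expected: the step is estimated as a 1.9-fold lower number from compound 3 to compound 4 (0.27 log units; within the scatter). For compound 4 the expected value in this assay is therefore 700 nM, with a likely range from 250 nM to 2000 nM.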

Compound 4, half-maximal effective concentration: 1050 nM
Beside the measured number, compound 4's estimate is 1.5-fold (0.18 log units) below it, and the stated range covers the measured number.
By their numbers in this assay, from the lowest: compound 2; then compounds 1, 4 and 3 (each within the scatter of the next).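

Putting 1H-pyrazol-1-yl in place of hydroxymethyl gives a 1.2-fold lower number from compound 3 to compound 4 (0.10 log units; within the scatter) and so no readable change, even though a five-membered aromatic ring with no hydrogen-bond donor enters. The same holds for the benzyl-bearing compound, where a 1.2-fold higher number from compound 1 to compound 4 (0.09 log units; within the scatter) leaves the two level, whereas a 5.9-fold higher number from compound 2 to compound 4 (0.77 log units; beyond the scatter) shows that among the four compounds only the 4-methylpiperazin-1-yl group of compound 2 stands apart at this position. No measurement at hand explains why that one group differs from the other three.

Still open, going by these compounds, is whether compound 2 owes its lower number to the whole 4-methylpiperazin-1-yl ring or whether a simpler amine, such as dimethylamino or a morpholine ring, would do the same on this chain. On these data alone, how a longer or shorter chain carrying 4-methylpiperazin-1-yl would compare also remains unknown.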